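A Methyl Group Placed Opposite the Ring Nitrogen

The source may hold more compounds than are shown below. What is called first, only, known or untested is meant among the compounds shown, and "the series" means these compounds.

Compound 1 `N/C(=N\NC(=S)N1CCCCCC1)c1ccccn1` and compound 2 `N/C(=N\NC(=S)N1CCOCC1)c1ccccn1` share much of their structure; the difference between the two cores is not broken down here. In a functional assay on MCF7 cells (Homo sapiens) for cytotoxicity, read by MTT assay, with a stated time of 72 h, tested at 100 uM (on this read-out higher numbers stand for more inhibition of growth at the one concentration tested and lower numbers for less inhibition of growth), compound 1 gives 84% and compound 2 gives 81.6%. Compound 3 `Cc1cccc(/C(N)=N/NC(=S)N2CCOCC2)n1` differs from compound 2 by methyl in place of hydrogen on an aromatic carbon, and this made the step of a number 6.9 percentage points lower from compound 2 to compound 3 (within the scatter), so compound 3 gives 74.7%. Compound 4 `Cc1ccnc(/C(N)=N/NC(=S)N2CCCCCC2)c1` differs from compound 1 by methyl in place of hydrogen on an aromatic carbon. It is the same kind of change, yet the place differs: in compound 3 the methyl sits next to the ring nitrogen, whereas in compound 4 it sits opposite the ring nitrogen. Because the step of a number 6.9 percentage points lower from compound 2 to compound 3 (within the scatter) stayed within the scatter, compound 4 is expected to move by a number 5 percentage points lower from compound 1 to compound 4 (within the scatter). In this assay compound 4 is estimated at 79%, between 66% and 90%.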

Compound 4, percent growth inhibition at one concentration: 65.4%
The estimate for compound 4 lay 13.6 percentage points above the measured number, and the stated range ends above it.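

In this assay, methyl in place of hydrogen on an aromatic carbon of the core of compound 1 gave a number 18.6 percentage points lower from compound 1 to compound 4 (beyond the scatter). Set beside the earlier methyl step, this does not show that the change acts differently on the two cores: the same change on two cores in this assay, a number 6.9 percentage points lower (within the scatter) from compound 2 to compound 3 and a number 18.6 percentage points lower (beyond the scatter) from compound 1 to compound 4, 11.7 percentage points apart, within the scatter of two such steps. Nor does it show that the change carries over unchanged: the cores differ, the methyl stands opposite the ring nitrogen only in compound 4, and two steps cannot tell place from core.

The compounds shown leave open how a methyl opposite the ring nitrogen behaves on the core of compound 2. They also leave open what a longer chain such as ethyl, or an amine, would do at that place.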